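Replacing the sulfamoyl group of compound 3

This account rests on a few compounds, and the source may have more. Where it says the series, first, only, none or still open, it means among the compounds named here.

Within the data shown here, in a functional assay on MIA PaCa-2 cells (Homo sapiens) for inhibition, read by MTT assay, with a stated time of 7 days (on this read-out lower numbers stand for stronger inhibition and higher numbers for weaker inhibition), compound 3 `CC(C)NS(=O)(=O)c1ccc(S(=O)(=O)N2CCC[C@@H](C(=O)N3CCN(c4nc(C(C)C)no4)CC3)C2)cc1` gives 2600 nM as the highest of three numbers so far, with compound 1 `CC(C)c1noc(N2CCN(C(=O)[C@@H]3CCCN(S(=O)(=O)c4ccc(S(=O)(=O)NC5CC5)cc4)C3)CC2)n1` at 1000 nM and compound 2 `CCN(CC)C(=O)c1ccc(S(=O)(=O)N2CCC[C@@H](C(=O)N3CCN(c4nc(C(C)C)no4)CC3)C2)cc1` at 100 nM for comparison. Compound 4 `CCC(CC)S(=O)(=O)c1ccc(S(=O)(=O)N2CCC[C@@H](C(=O)N3CCN(c4nc(C(C)C)no4)CC3)C2)cc1` carries pentan-3-yl in place of isopropylamino on a sulfonyl sulfur and so no longer has a sulfamoyl group. Changing only the group on the sulfonamide nitrogen gave a 2.6-fold higher number from compound 1 to compound 3 (0.41 log units; beyond the scatter) as a modest step. Steps that replace the whole sulfamoyl group were larger, at a 10-fold lower number from compound 1 to compound 2 (1.00 log units; beyond the scatter) and a 26-fold higher number from compound 2 to compound 3 (1.41 log units; beyond the scatter) in the data. Compound 4 also replaces that whole group, so the step expected in this assay is a 5.2-fold lower number from compound 3 to compound 4 (0.72 log units; beyond the scatter) with real uncertainty. Compound 4 is estimated at 500 nM within a range of 100 nM to 2500 nM overall.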

Compound 4, half-maximal inhibitory concentration: 50 nM
Estimate against measurement, compound 4: 10-fold (1.00 log units) above; the whole stated range lies above it.
By their numbers in this assay, from the lowest: compounds 4 and 2 (each within the scatter of the next); then compound 1; then compound 3.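

On the sulfonyl sulfur, an amino group is not required for activity in this assay: pentan-3-yl in place of isopropylamino gives a 52-fold lower number from compound 3 to compound 4 (1.72 log units; beyond the scatter) and in place of cyclopropylamino gives a 20-fold lower number from compound 1 to compound 4 (1.30 log units; beyond the scatter). The (pentan-3-yl)sulfonyl and diethylcarbamoyl groups cannot be told apart here, with a 2.0-fold lower number from compound 2 to compound 4 (0.30 log units; within the scatter). Nothing available explains why removing the amino group changes the number so much. Still open, going by these compounds, is whether the branched pentan-3-yl chain itself matters. Methyl or cyclopentyl on the same sulfur would help to test this.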